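A few compounds are considered here, and "the series" means these few. Any claim that something is new, unique, unknown or untested is made for them only; others in the source may bear on it.

Measured so far:
Compound 1, `CCOC(=O)c1c(-c2cccc(C(F)(F)F)c2)[nH]c2cc(OC)ccc2c1=O`: in a physicochemical assay for solubility, in phosphate buffer, at pH 7.4 (on this read-out lower numbers stand for lower solubility and higher numbers for higher solubility), compound 1 gives 19000 nM.
Compound 2, `CCOC(=O)c1c(-c2ccc(Cl)cc2)[nH]c2cccc(OC)c2c1=O`: in this assay compound 2 gives > 100000 nM, which is a limit of the assay and not a number.

Compound 1 holds the only plain number shown, the other value being a limit, (the limit of > 100000 nM in this assay, at which 1 of the 2 values shown sits). Compound 3, `CCOC(=O)c1c(-c2cccc(OC)c2)[nH]c2cc(OC)ccc2c1=O`, differs from compound 1 in one place: methoxy in place of trifluoromethyl on an aromatic carbon. Going by the values given here, no step between two measured compounds is at hand, so the size of this change in this assay cannot be read from the data; a modest rise, somewhat beyond the scatter, is expected, a 2.1-fold higher number from compound 1 to compound 3 (0.32 log units; beyond the scatter). Compound 3 is estimated at 40000 nM, between 15000 nM and 100000 nM.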

Compound 3, solubility: > 100000 nM
Compound 3 gave a limit, no number; the forecaster's own chance of this, stated with the estimate: 20%; middle value at least 2.5-fold (0.39 log units) from the limit.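

Methoxy in place of trifluoromethyl on an aromatic carbon gives an at least 5.2-fold higher number from compound 1 to compound 3 (0.72 log units; beyond the scatter) in this assay and this step lies beyond the scatter. Going by these compounds alone, this is the first direct measure of a change at this position. Compound 3 gives a limit and not a number, so only the smallest possible size of the change can be read: the limit of > 100000 nM in this assay, at which 2 of the 3 values shown sit.

From the compounds shown here alone, whether an amine or a carboxylic acid on this aromatic carbon would give a plain number remains open. Compound 2 differs from compound 1 in more than one place, so it cannot settle this.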